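The source may hold more compounds than are shown below. What is called first, only, known or untested is meant among the compounds shown, and "the series" means these compounds.

The three measured compounds and their values:

Compound 1 `COC(=O)c1c(-c2ccc([N+](=O)[O-])cc2)oc2ccccc2c1=O` in a functional assay on HT-29 cells (Homo sapiens) for cytotoxicity, read by MTT assay, with a stated time of 6 days (on this read-out lower numbers stand for an effect already at smaller amounts and higher numbers for an effect only at larger amounts of compound), gives > 25 ug/mL, which is a limit of the assay rather than a number.

Compound 2 `COC(=O)c1c(-c2ccc(O)cc2)oc2ccccc2c1=O` in this assay gives > 25 ug/mL, again only a limit.

Compound 3 `COc1ccc2oc(-c3ccc([N+](=O)[O-])cc3)c(C(=O)O)c(=O)c2c1` in this assay gives > 25 ug/mL, again only a limit.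

Compound 1 and compound 2 differ in one place: hydroxy in place of nitro on an aromatic carbon. The step this change made is a step that the two limits leave unreadable from compound 1 to compound 2; with both values sitting at a limit, its size cannot be read. Compound 4 `COc1ccc2oc(-c3ccc(O)cc3)c(C(=O)O)c(=O)c2c1` has not yet been measured. It stands to compound 3 as compound 2 stands to compound 1: hydroxy in place of nitro on an aromatic carbon. The two place descriptions match word for word, so this is the same change, and among the compounds here it occurs twice in all. How the core of compound 3 differs from the core of compound 1 is not broken down here.

What the three measurements share is the limit of > 25 ug/mL in this assay, at which 3 of the 3 values shown sit. The earlier instance of the change is unreadable, and every value shown is a limit, so the expectation for compound 4 rests on that shared limit alone. Compound 4 is expected to move a step that the limit leaves unreadable from compound 3 to compound 4 in this assay, a small step placed beside the unreadable earlier one, because the limit of > 25 ug/mL in this assay, at which 3 of the 3 values shown sit, is all that the shared pattern offers. Compound 4 is expected to give about 35 ug/mL. The lower end expected for compound 4 is 12 ug/mL. The upper end expected for compound 4 is 110 ug/mL.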

Compound 4, concentration for half-maximal effect: > 25 ug/mL
Compound 4: only a limit was reported (the forecaster's own chance of this, stated with the estimate: 75%); the middle value lies beyond the limit too.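

In this assay no size can be read for the change from nitro to hydroxy between compound 3 and compound 4, and the same holds for compound 1 and compound 2; what stands is only this: the limit of > 25 ug/mL in this assay, at which 4 of the 4 values shown sit. The compounds shown leave open whether this change moves the value at all, in which direction, and what amount of any of them would give a half-maximal effect.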